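Oxazole carbon substitution in a ketooxazole FAAH series

The compounds below may be only part of what the source reports. "The series", "measured", "known", "first", "only" and "open" are said of these compounds alone.

Measured so far:
compound 1 `O=C(CCc1ccc(-c2ccccc2)cc1)c1ncc(-c2ccncc2)o1`: 2.3 nM
compound 2 `CN(C)C(=O)c1cnc(C(=O)CCc2ccc(COc3ccccc3)cc2)o1`: 6.7 nM

Both compounds were run in an assay for inhibition of Fatty-acid amide hydrolase 1 (Rattus norvegicus); a lower number here means a stronger inhibitor, a higher number a weaker inhibitor. Compound 1 gives 2.3 nM, and compound 2 gives 6.7 nM, the higher of the two numbers; the gap between them is beyond the usual scatter, so compound 2 is the weaker inhibitor of the pair on these data. For the measured compounds named here, the two compounds differ in more than one place, so no single step between them can be read off.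

Compound 3 `O=C(CCc1ccc(COc2ccccc2)cc1)c1ncc(-c2cccc(-c3nnn[nH]3)n2)o1` keeps the whole of compound 2 apart from one change on the aromatic carbon of the shared five-membered ring: 6-(1H-tetrazol-5-yl)pyridin-2-yl in place of dimethylcarbamoyl on an aromatic carbon. Compound 1 shows that a pyridyl attached at this carbon sits with a strong number, while compound 2 shows that a dimethylcarbamoyl there also sits within a tight range. Going by the values given here, no measured step covers this exact exchange, so the direction is uncertain; the expectation for the step from compound 2 to compound 3 is a 1.1-fold lower number from compound 2 to compound 3 (0.05 log units; within the scatter), a move not clearly beyond the scatter. Compound 3 is therefore estimated at 6 nM, with a range of 1.5 nM to 25 nM.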

Compound 3, inhibition constant: 21 nM
Estimate against measurement, compound 3: 3.5-fold (0.54 log units) below; the measured number falls inside the stated range.
By their numbers in this assay, from the lowest: compound 1; then compound 2; then compound 3.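

In this assay, for the compounds shown here, 6-(1H-tetrazol-5-yl)pyridin-2-yl in place of dimethylcarbamoyl on the aromatic carbon next to the ring oxygen gives a 3.1-fold higher number from compound 2 to compound 3 (0.50 log units; beyond the scatter), the first single-place reading at this position. The step is modest but beyond the scatter, and it shows that this carbon accepts a substituent with two aromatic rings and a hydrogen-bond donor at a measurable cost, with compound 3 still at 21 nM. No measured property of these compounds bears on the size of this step, so the data offer no account of it.

A single step cannot separate the contribution of the pyridine ring from that of the 1H-tetrazol-5-yl group, and an unsubstituted pyridin-2-yl or a carboxylic acid in place of the 1H-tetrazol-5-yl group on the same core would address that question. From the compounds shown here alone, whether the step carries over to the side chain of compound 1 also remains open, as compound 1 differs from compound 3 in more than one place.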